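This account rests on a few compounds, and the source may have more. Where it says the series, first, only, none or still open, it means among the compounds named here.

Measured so far in a functional assay on LNCaP cells (Homo sapiens) for antiproliferative activity; on this read-out higher numbers stand for weaker inhibition and lower numbers for stronger inhibition:
- compound 1 `Cn1ncc(Cl)c1-c1cc(C(=O)N[C@@H]2CN[C@H](CCO)C[C@H]2c2ccc(F)c(F)c2)oc1Cl` at 60 nM
- compound 2 `Cn1ncc(Cl)c1-c1cc(C(=O)N[C@@H]2CN[C@H](CCN3CCCCC3)C[C@H]2c2ccc(Cl)c(Cl)c2)oc1Cl` at 1780 nM
- compound 3 `CNC(=O)C[C@@H]1C[C@@H](c2ccc(F)c(F)c2)[C@H](NC(=O)c2cc(-c3c(Cl)cnn3C)c(Cl)o2)CN1` at 50 nM

Compound 2 has the highest number of the three, beyond the scatter from both others. Compound 4 `Cn1ncc(Cl)c1-c1cc(C(=O)N[C@@H]2CN[C@H](CC(=O)NCC(O)CO)C[C@H]2c2ccc(Cl)c(Cl)c2)oc1Cl` carries (2,3-dihydroxypropyl)carbamoyl in place of the (piperidin-1-yl)methyl of compound 2, on a saturated chain carbon bound to a saturated ring carbon ((2,3-dihydroxypropyl)carbamoyl in place of (piperidin-1-yl)methyl on a saturated chain carbon bound to a saturated ring carbon). Going by the values given here, no measured step covers this change directly. The only one available (a 1.2-fold lower number from compound 1 to compound 3 (0.08 log units; within the scatter)) puts methylcarbamoyl in place of hydroxymethyl at that place and stays within the scatter. Compound 3 also has a carbamoyl group there and gives 50 nM but differs from compound 2 elsewhere as well, so the transfer is uncertain. The expected step in this assay is a 14-fold lower number from compound 2 to compound 4 (1.14 log units; beyond the scatter) and points to a lower number, beyond the scatter. The estimated value for compound 4 is 130 nM (expected range 35 nM to 600 nM).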

Compound 4, half-maximal inhibitory concentration: 660 nM
The estimate for compound 4 lay 5.1-fold (0.71 log units) below the measured number; measured number outside the range, above it.
By their numbers in this assay, from the lowest: compounds 3 and 1 (each within the scatter of the next); then compound 4; then compound 2.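

Replacing (piperidin-1-yl)methyl with (2,3-dihydroxypropyl)carbamoyl on a saturated chain carbon bound to a saturated ring carbon gives in this assay a 2.7-fold lower number from compound 2 to compound 4 (0.43 log units; beyond the scatter) as a modest change beyond the scatter. Going by these compounds alone, the only earlier step at this place, a 1.2-fold lower number from compound 1 to compound 3 (0.08 log units; within the scatter) and involving other groups, stayed within the scatter. No supporting data bear on the origin of the new step.

Which part of the change carries the step stays open: loss of the ring or entry of the carbamoyl. Also open, going by these compounds, is how a carboxylic acid or a primary amine on the same chain would read out on the core of compound 2.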